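The source may report more compounds than this note shows. Statements on the series, on what has been measured and on what is new or still open speak of the compounds shown alone.

Of the compounds shown here, two have so far been measured in an ADME assay on microsomes from liver (Homo sapiens) for metabolic stability; on this read-out lower numbers stand for a shorter-lived compound and higher numbers for a longer-lived compound. Compound 1 `CC(C)C(/C=C1\OC(=O)NC1=O)c1cc(Cl)c(-c2ccc3cccc(F)c3c2)[nH]c1=O` gives > 3 h in this assay, and that figure is a limit of the measurement rather than a number. Compound 2 `CC(C)[C@@H](c1ccc(-c2ccc3cccc(F)c3c2)[nH]c1=O)[C@H]1OC(=O)NC1=O` gives > 3 h in this assay, again a limit and not a number. Compound 2 thus stands exactly where every value shown so far sits, namely at the limit of > 3 h in this assay, at which 2 of the 2 values shown sit; nothing in these results tells compound 1 and compound 2 apart.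

Compound 3 `CC(C)[C@H](C[C@@H]1OC(=O)NC1=O)c1ccc(-c2ccc3cccc(F)c3c2)[nH]c1=O` has not yet been measured. It differs from compound 2 in a single place: (2,4-dioxo-1,3-oxazolidin-5-yl)methyl in place of 2,4-dioxo-1,3-oxazolidin-5-yl on a saturated chain carbon bound to an aromatic carbon and a saturated chain carbon. Within the data shown here, no pair of measured compounds differing in one place exists here, so no measured step can guide the size of this change. Because both values shown rest at the limit of > 3 h in this assay, at which 2 of the 2 values shown sit, the step expected for compound 3 is a number no higher from compound 2 to compound 3 (the limit leaves the size open), nothing beyond the usual scatter of this assay. Compound 3 is therefore estimated to give 3 h in this assay, with a range from 1.5 h to 6 h, and quite possibly only a limit once more.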

Compound 3, half-life: 2.07 h
Compound 3: middle estimate off by 1.4-fold (0.16 log units), on the high side, within the range that was stated.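

In this assay, among these compounds, compound 3 gives 2.07 h, the first true number in this small set and so the first reading at this position that is not a limit. Placing (2,4-dioxo-1,3-oxazolidin-5-yl)methyl in place of 2,4-dioxo-1,3-oxazolidin-5-yl on the saturated chain carbon gives an at least 1.4-fold lower number from compound 2 to compound 3 (0.16 log units; that floor lies within the scatter), so this one-place change can be followed by a number, though its floor does not clear the usual scatter of repeated measurements. The real size of the step remains unknown, and the lengthened link cannot yet be said to shorten the half-life beyond that scatter, because the starting point of the comparison is a limit and not a number: the limit of > 3 h in this assay, at which 2 of the 3 values shown sit.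

The compounds shown leave open what a longer chain carrying the same ring, or a carboxylic acid or an amine in place of the ring, would do to the half-life at this position. They also leave open whether the same change would give a similar result on the core of compound 1, which carries a chlorine on its ring.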